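Swapping the amine on a dithiocarbamate chromone

The compounds below may be only part of what the source reports. "The series", "measured", "known", "first", "only" and "open" are said of these compounds alone.

Measured compounds in a functional assay on HeLa cells (Homo sapiens) for antiproliferative activity, read by MTT assay, with a stated time of 72 h; on this read-out higher numbers stand for weaker inhibition and lower numbers for stronger inhibition:
compound 1, `Cc1ccc2c(=O)c(CSC(=S)N(C(C)C)C(C)C)coc2c1`, 1400 nM
compound 2, `O=c1c(Cl)c(CSC(=S)N2CCCCC2)oc2ccccc12`, 9800 nM
compound 3, `CC(C)N(C(=S)SCc1coc2ccccc2c1=O)C(C)C`: here the value is only a limit of the assay, > 30000 nM

Compound 1 gives the lowest of the two numbers shown, and compound 2 gives the higher of the two, with the gap between them beyond the usual scatter. The only one-place step shown is an at least 21-fold higher number from compound 1 to compound 3 (1.33 log units; beyond the scatter). Compound 4, `Cc1ccc2c(=O)c(CSC(=S)N3CCCCC3)coc2c1`, differs from compound 1 by piperidin-1-yl in place of diisopropylamino on a thiocarbonyl carbon. Within the data shown here, no measured step covers this change; compound 2 carries piperidin-1-yl but differs from compound 3 in two places, so it only shows that a piperidin-1-yl compound can give a number. Compound 4 is therefore expected close to compound 1, with the step of a 1.8-fold higher number from compound 1 to compound 4 (0.25 log units; within the scatter), giving an estimate of 2500 nM (range 800 nM to 10000 nM).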

Compound 4, half-maximal inhibitory concentration: > 25000 nM
Compound 4: only a limit was reported; the forecaster's own chance of this, stated with the estimate: 10%; middle value at least 10-fold (1.00 log units) away from the limit.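

In this assay, the amine on the thiocarbonyl carbon turns out to matter as much as the methyl on the core: piperidin-1-yl in place of diisopropylamino gives an at least 17-fold higher number from compound 1 to compound 4 (1.25 log units; beyond the scatter). Compound 4 gives > 25000 nM, which is a limit of the assay and not a number. The full size of this step stays unknown because compound 4 sits at a limit: the limit of > 25000 nM in this assay, at which 1 of the 4 values shown sits.

Still open, going by these compounds, is whether another amine, such as morpholine or dimethylamine, would keep the activity of compound 1. The compounds shown also do not explain why the swap costs so much.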